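A few compounds are considered here, and "the series" means these few. Any claim that something is new, unique, unknown or untested is made for them only; others in the source may bear on it.

Measured values in a functional assay with Homo sapiens as the target; a higher number here means a weaker inhibitor, a lower number a stronger inhibitor:
- compound 1 `CC(C)[C@H](NC(=O)COc1cccc2ccccc12)C(=O)N[C@@H](CC(=O)O)C(=O)COc1ccc(C(F)(F)F)cc1`: 12300 nM
- compound 2 `CC(C)[C@H](NC(=O)COc1cccc2ccccc12)C(=O)N[C@@H](CC(=O)O)C(=O)COc1ccccc1[N+](=O)[O-]`: 27700 nM
- compound 3 `CC(C)[C@H](NC(=O)COc1cccc2ccccc12)C(=O)N[C@@H](CC(=O)O)C(=O)COc1c(F)cc(F)cc1F`: 14900 nM

Compound 3 stands within the scatter of both other compounds, as a 1.2-fold higher number from compound 1 to compound 3 (0.08 log units; within the scatter) and a 1.9-fold lower number from compound 2 to compound 3 (0.27 log units; within the scatter) show. Going by the values given here, compound 4 `CC(C)[C@H](NC(=O)COc1cccc2ccccc12)C(=O)N[C@@H](CC(=O)O)C(=O)COc1c(Cl)cccc1Cl` keeps the shared core and changes only one group: 2,6-dichlorophenyl in place of 2,4,6-trifluorophenyl on an oxygen on a saturated carbon. In words, it carries 2,6-dichlorophenyl in place of 2,4,6-trifluorophenyl on an oxygen on a saturated carbon. All three measured steps swap this same group. The only one beyond the scatter is modest: a 2.3-fold higher number from compound 1 to compound 2 (0.35 log units; beyond the scatter). From the compounds shown here alone, no step beyond the scatter is therefore expected in this assay, though the direction stays open. The expected step is a 1.0-fold higher number from compound 3 to compound 4 (0.00 log units; within the scatter). For compound 4 the estimated value is 15000 nM, with an expected range of 7500 nM to 30000 nM.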

Compound 4, half-maximal inhibitory concentration: 15300 nM
For compound 4 the middle estimate is 1.0-fold (0.01 log units) below the measured one; the measured number falls inside the stated range.
By their numbers in this assay, from the lowest: compounds 1, 3, 4 and 2 (each within the scatter of the next, the first and the last beyond it).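

With 2,6-dichlorophenyl, chlorine joins the groups on this oxygen, and compound 4 lies within the scatter of all three earlier compounds (a 1.0-fold higher number from compound 3 to compound 4 (0.01 log units; within the scatter)) (a 1.2-fold higher number from compound 1 to compound 4 (0.09 log units; within the scatter)) (a 1.8-fold lower number from compound 2 to compound 4 (0.26 log units; within the scatter)). In this assay, going by these compounds alone, the step from 2,4,6-trifluorophenyl to this group therefore gives no readable change, and compounds 1 and 2 remain the only pair beyond the scatter. Nothing available explains this result.

The compounds shown leave open how a phenyl ring carrying an amine or a carboxylic acid would read in this assay. The same question stands for a plain alkyl chain in place of the ring.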